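Ester side chains on a shared core: compound 3 next

The source may report more compounds than this note shows. Statements on the series, on what has been measured and on what is new or still open speak of the compounds shown alone.

Values in a functional assay on DU-145 cells (Homo sapiens) for cytotoxicity, read by MTT assay; on this read-out higher numbers stand for weaker inhibition and lower numbers for stronger inhibition:
- compound 1 `CCCC(O)CC(=O)O[C@H](CC=C(C)C)C1=CC(=O)c2c(O)ccc(O)c2C1=O`: > 100000 nM, a limit of the assay
- compound 2 `CC(C)=CC[C@@H](OC(=O)C1CCOC1)C1=CC(=O)c2c(O)ccc(O)c2C1=O`: 47500 nM

Going by the values given here, compound 2 holds the only actual number so far. Compound 3 `CC(C)=CC[C@@H](OC(=O)CC(C)(O)c1ccccc1)C1=CC(=O)c2c(O)ccc(O)c2C1=O` keeps the shared core and alters the ester side chain, with 2-hydroxy-2-phenylpropyl in place of oxolan-3-yl on a carbonyl carbon.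

Among the compounds with values here, the one measured step that bears on this is an at least 2.1-fold lower number from compound 1 to compound 2 (0.32 log units; beyond the scatter), which put oxolan-3-yl in place of 2-hydroxypentyl at that same place. Within the data shown here, the entering group is again a 2-hydroxy chain, so an at least 2.1-fold lower number from compound 1 to compound 2 (0.32 log units; beyond the scatter) hints at a higher number, but its six-membered aromatic ring has no measured counterpart. No change beyond the scatter is therefore expected, and the estimated step is a 1.1-fold lower number from compound 2 to compound 3 (0.02 log units; within the scatter). For compound 3 the estimated value is 45000 nM, with an expected range of 14000 nM to 100000 nM.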

Compound 3, half-maximal inhibitory concentration: > 100000 nM
Compound 3 gave a limit, no number; the forecaster's own chance of this, stated with the estimate: 20%; middle value at least 2.2-fold (0.34 log units) from the limit.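

In this assay, 2-hydroxy-2-phenylpropyl in place of oxolan-3-yl on a carbonyl carbon gives an at least 2.1-fold higher number from compound 2 to compound 3 (0.32 log units; beyond the scatter). Compound 3 reads > 100000 nM, which is a limit of the assay and not a number. The side chain on this carbonyl carbon has now been exchanged in both directions around oxolan-3-yl, and the entering six-membered aromatic ring does not keep the measured value of compound 2, so the two side chains carrying a hydroxyl group, in compound 1 and compound 3, both stand at the limit: the limit of > 100000 nM in this assay, at which 2 of the 3 values shown sit.

The step between compound 1 and compound 3 cannot be read, so these two side chains cannot be ranked. Open too, on these data alone, is whether a plain phenyl group without the hydroxyl, or an amine on this side chain, would give a number rather than a limit.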